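The source may hold more compounds than are shown below. What is called first, only, known or untested is meant among the compounds shown, and "the series" means these compounds.

Series notes: two bis-benzylidene cyclohexanones of a shared core have been read in a functional assay on SW-620 cells (Homo sapiens) for cytotoxicity, read by MTT assay, with a stated time of 72 h (on this read-out lower numbers stand for stronger inhibition and higher numbers for weaker inhibition), and a third awaits the same read-out.

Compound 1 is `COc1cccc(/C=C2\CCC/C(=C\c3ccc(O)cc3)C2=O)c1OC`. In this assay compound 1 gives only a limit, > 20000 nM, not a number, so it sits at the limit of > 20000 nM in this assay, at which 1 of the 2 values shown sits.

Compound 2 is `COc1ccc(/C=C2\CCC/C(=C\c3ccccc3Cl)C2=O)cc1OC`. In this assay compound 2 gives 7100 nM. Within the data shown here, this is the only number in the set so far; the one other value is the limit just named, so compound 2 stands alone as the single measured point.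

Compound 3 is `COc1ccc(/C=C2\CCC/C(=C\c3ccc(Cl)c(Cl)c3)C2=O)cc1OC`. It differs from compound 2 by 3,4-dichlorophenyl in place of 2-chlorophenyl on a double-bonded chain carbon bound to a double-bonded ring carbon.

Among the measured compounds shown here, no step between two measured compounds exists here, so the expectation for compound 3 rests on the single number from compound 2 and on the change itself. A step toward stronger inhibition of roughly a 1.8-fold lower number from compound 2 to compound 3 (0.25 log units; within the scatter) is expected from compound 2 to compound 3, a size that only just reaches beyond the usual scatter.

On that basis compound 3 is estimated at 4000 nM in this assay, expected to fall between 1500 nM and 15000 nM.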

Compound 3, half-maximal inhibitory concentration: 4000 nM
For compound 3 middle estimate and measured number coincide at the digits printed, and the stated range covers the measured number.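

In this assay, the swap of 2-chlorophenyl for 3,4-dichlorophenyl on a double-bonded chain carbon bound to a double-bonded ring carbon gives a 1.8-fold lower number from compound 2 to compound 3 (0.25 log units; within the scatter) as the first step readable in the series. This place therefore accepts a second chlorine and a different chlorine pattern on the phenyl ring without a change that can be told from the usual scatter, and the two compounds cannot be ranked on this read-out. Nothing at hand gives a cause for this step.

Among these compounds, compound 1 gives only > 20000 nM as a limit and differs from compound 2 in more than one place, so no step to it can be read, and the role of its hydroxyl and the methoxy pattern stays unresolved. Also open is whether a group of another kind on this phenyl ring, such as an amine or a carboxylic acid, would move the number beyond the scatter, since the two chlorinated rings shown span only a narrow choice at this place.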